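The source may report more compounds than this note shows. Statements on the series, on what has been measured and on what is new or still open speak of the compounds shown alone.

For the measured compounds named here, compound 1 `COc1cccc(/C=C/C(=O)c2c(OC)cc(OC)cc2OC)c1` is one of three compounds measured in a functional assay on Huh-7 cells (Homo sapiens), read by fluorescence and BrdU incorporation, with a stated time of 48 h, tested at 25 uM; on this read-out higher numbers stand for a weaker effect at the one concentration tested and lower numbers for a stronger effect; there compound 1 gives 0.3%. Compound 2 `COc1cc(OC)c(C(=O)/C=C/c2ccc(Cl)cc2)c(OC)c1` gives 0.8% and compound 3 `COc1cc(OC)c(C(=O)/C=C/c2ccc(Br)cc2)c(OC)c1` gives 0.2%, so compound 1 stands second highest of the three, with a number 0.5 percentage points higher from compound 1 to compound 2 (within the scatter), a number 0.1 percentage points lower from compound 1 to compound 3 (within the scatter) and a number 0.6 percentage points lower from compound 2 to compound 3 (within the scatter). Compound 4 `COc1cccc(/C=C/C(=O)c2c(O)cc(OC)cc2OC)c1` differs from compound 1 by hydrogen in place of methyl on an oxygen on an aromatic ring. Going by the values given here, none of the measured steps touches this oxygen; all three replace the aryl group on the double-bonded chain carbon, and all remain within the scatter. There is thus no measured basis for expecting a step beyond the scatter, and a number 0.7 percentage points higher from compound 1 to compound 4 (within the scatter) is the change expected. Compound 4 is therefore estimated at 1%, between 0% and 10%.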

Compound 4, a percentage reported as activity, at one concentration (the size of the read-out at that concentration, not a potency): 8.5%
Estimate against measurement, compound 4: 7.5 percentage points below; the range from low to high includes it.
By their numbers in this assay, from the lowest: compounds 3, 1, 2 and 4 (each within the scatter of the next).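

The step from methoxy to hydroxy is the only one shown on an oxygen on an aromatic ring, and in this assay it gives a number 8.2 percentage points higher from compound 1 to compound 4 (within the scatter). Removing this methyl therefore does not move the read-out beyond the scatter at the one concentration tested, so this position, like the aryl group on the chain, shows no measured effect. Nothing shown accounts for the size of this step.

The compounds shown leave open whether an ethoxy group or an amine on this aromatic carbon would give a step beyond the scatter. They also leave open whether hydroxy in place of methoxy would read the same alongside the 4-chlorophenyl or 4-bromophenyl group.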